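The source may report more compounds than this note shows. Statements on the series, on what has been measured and on what is new or still open speak of the compounds shown alone.

Of the compounds shown here, three have been tested in a functional assay on the whole organism (strain Wistar albino) for inhibition, with Rattus norvegicus as the target, read by paw edema, with a stated time of 1 h, at a dose of 40 mg/kg by the oral route; on this read-out higher numbers stand for more inhibition at the one dose given (going by the name of the read-out) and lower numbers for less inhibition. Compound 1 `COc1ccc(N2C(=O)CSC2c2sc(-c3ccccc3)nc2C)cc1` gives 52.3%, compound 2 `COc1ccc(N2C(=O)CSC2c2sc(Cc3ccc(Cl)cc3)nc2C)cc1` gives 20.9%, and compound 3 `Cc1ccc(N2C(=O)CSC2c2sc(-c3ccc(Cl)cc3)nc2C)cc1` gives 38.3%. Compound 3 thus stands second of the three, below compound 1 and above compound 2, with both gaps beyond the scatter. Compound 4 `COc1ccc(N2C(=O)CSC2c2sc(-c3ccc(Cl)cc3)nc2C)cc1` is not yet measured and differs from compound 3 in one place: methoxy in place of methyl on an aromatic carbon. Among the compounds with values here, the only single-place step on record, a number 31.4 percentage points lower from compound 1 to compound 2 (beyond the scatter), alters a different part of the molecule and bears little on this change. Compound 1 also carries methoxy and sits highest in this assay, but it differs from compound 3 in two places. The change is therefore expected to be modest and upward, a number 6.7 percentage points higher from compound 3 to compound 4 (within the scatter). Compound 4 is estimated at 45%, between 30% and 60%.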

Compound 4, a percentage reported as inhibition, in the whole organism at one dose (the size of the read-out at that dose, not a potency): 54%
For compound 4 the middle estimate is 9 percentage points below the measured one, within the range that was stated.
By their numbers in this assay, from the lowest: compound 2; then compound 3; then compounds 1 and 4 (each within the scatter of the next).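

Methoxy in place of methyl, para to a large group, now has its first single-place reading, and it is a real gain (a number 15.7 percentage points higher from compound 3 to compound 4 (beyond the scatter)). Chloro in place of hydrogen on the phenyl ring changes little (a number 1.7 percentage points higher from compound 1 to compound 4 (within the scatter)), whereas 4-chlorophenyl in place of 4-chlorobenzyl matters greatly (a number 33.1 percentage points higher from compound 2 to compound 4 (beyond the scatter)). No evidence at hand accounts for these shifts.

Going by these compounds, whether an amine or a longer ether such as ethoxy at this place would match methoxy remains open. So does whether the methoxy gain holds without the chloro group.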